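The compounds below may be only part of what the source reports. "The series", "measured", "known", "first", "only" and "open" are said of these compounds alone.

In a physicochemical assay for lipophilicity (on this read-out lower numbers stand for lower lipophilicity and higher numbers for higher lipophilicity), compound 1 `C[C@H]1CC[C@@H]2[C@@H](OC(=O)[C@]23CC(c2ccc(Cl)cc2)=NO3)[C@]2(C)C(=O)C=C[C@@]12O` gives 2.09, compound 2 `C[C@H]1CC[C@@H]2[C@@H](OC(=O)[C@]23CC(c2ccc(N(C)C)cc2)=NO3)[C@]2(C)C(=O)C=C[C@@]12O` gives 1.51 and compound 3 `C[C@H]1CC[C@@H]2[C@@H](OC(=O)[C@]23CC(c2ccc([N+](=O)[O-])cc2)=NO3)[C@]2(C)C(=O)C=C[C@@]12O` gives 1.37. Compound 3 cannot be told apart from compound 2, with a number 0.14 log units lower from compound 2 to compound 3 (within the scatter), but it sits under compound 1, with a number 0.72 log units lower from compound 1 to compound 3 (beyond the scatter). Compound 4 `C[C@H]1CC[C@@H]2[C@@H](OC(=O)[C@]23CC(c2ccccc2Cl)=NO3)[C@]2(C)C(=O)C=C[C@@]12O` differs from compound 3 in one place: 2-chlorophenyl in place of 4-nitrophenyl on a carbon with a double bond to nitrogen. The step between compound 1 and compound 3 is the closest guide, read in reverse, as it exchanges chloro and nitro on an aromatic carbon. For the measured compounds named here, no measured compound carries 2-chlorophenyl itself, however, so the guide is imperfect. A modest rise in this assay is therefore expected, and the expected step is a number 0.63 log units higher from compound 3 to compound 4 (beyond the scatter). For compound 4 the estimated value is 2, within an expected range of 1.6 to 2.4.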

Compound 4, partition coefficient: 2.09
Compound 4: middle estimate off by 0.09 log units, on the low side, within the range that was stated.
By their numbers in this assay, from the lowest: compounds 3 and 2 (each within the scatter of the next); then compounds 1 and 4 (each within the scatter of the next).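

On the carbon with a double bond to nitrogen, 2-chlorophenyl and 4-chlorophenyl cannot be told apart in this assay, with no change at the digits printed from compound 1 to compound 4 (within the scatter), so where the chlorine sits on the phenyl ring makes no readable difference between these two compounds. Against the other two groups, 2-chlorophenyl stands clear of both, with a number 0.72 log units higher from compound 3 to compound 4 (beyond the scatter) and a number 0.58 log units higher from compound 2 to compound 4 (beyond the scatter). No measurement shown explains these steps. The compounds shown leave open whether 2-nitrophenyl would match 4-nitrophenyl as closely, and how unsubstituted phenyl or 4-methoxyphenyl would read at this position.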